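A few compounds are considered here, and "the series" means these few. Any claim that something is new, unique, unknown or untested is made for them only; others in the source may bear on it.

Measured in an ADME assay on BV-2 cells (Mus musculus) for cytotoxicity, read by MTT assay, with a stated time of 48 h, tested at 1 uM; a higher number here means a weaker effect of the compound at the concentration tested, a lower number a stronger effect:
compound 1 `O=C1COCCN1c1ccc(/N=C\c2c[nH]c3ccccc23)cc1` gives 105%
compound 2 `O=C1COCCN1c1ccc(/N=C\c2cn(C(=O)c3ccccc3)c3ccccc23)cc1` gives 109%
compound 3 `O=C1COCCN1c1ccc(/N=C\c2cn(C(=O)c3ccc(Cl)cc3)c3ccccc23)cc1` gives 97.6%

Compound 3 stands against compound 1 by a number 7.4 percentage points lower from compound 1 to compound 3 (within the scatter) and against compound 2 by a number 11.4 percentage points lower from compound 2 to compound 3 (beyond the scatter); only the second of these steps exceeds the scatter. Compound 4 `O=C1COCCN1c1ccc(/N=C\c2cn(Cc3ccccc3)c3ccccc23)cc1` differs from compound 3 by benzyl in place of (4-chlorophenyl)carbonyl on an aromatic nitrogen. For the measured compounds named here, the steps that bear on this are a number 11.4 percentage points lower from compound 2 to compound 3 (beyond the scatter), the single step beyond the scatter, and a number 7.4 percentage points lower from compound 1 to compound 3 (within the scatter), both changes on the same aromatic nitrogen or its substituent. With the chloro gone in compound 4 and the whole group replaced by benzyl, a small move back toward compound 1 and compound 2 is expected, so a number 6.4 percentage points higher from compound 3 to compound 4 (within the scatter) is the expected step, within the scatter. Compound 4 is estimated at 104%, between 93% and 115%.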

Compound 4, a percentage reported as activity, at one concentration (the size of the read-out at that concentration, not a potency): 89.3%
For compound 4 the middle estimate is 14.7 percentage points above the measured one; measured number outside the range, below it.
By their numbers in this assay, from the lowest: compounds 4, 3, 1 and 2 (each within the scatter of the next, the first and the last beyond it).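

In this assay, for the compounds shown here, benzyl is the one group on this aromatic nitrogen that stands beyond the scatter from the free nitrogen (a number 15.7 percentage points lower from compound 1 to compound 4 (beyond the scatter)), whereas benzoyl and (4-chlorophenyl)carbonyl do not; it also stands beyond the scatter from benzoyl (a number 19.7 percentage points lower from compound 2 to compound 4 (beyond the scatter)). Against (4-chlorophenyl)carbonyl the change stays within the scatter (a number 8.3 percentage points lower from compound 3 to compound 4 (within the scatter)), so these two groups cannot be ordered. Nothing available explains the benzyl result. Open, on these data alone, is how a chloro on the benzyl ring, a longer phenylalkyl chain or an aminoalkyl chain on this nitrogen would read. A read-out at one concentration also leaves the concentration dependence of these differences open.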